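Nitrobenzamide series: chlorophenyl to difluorophenyl on the aromatic carbon

The source may hold more compounds than are shown below. What is called first, only, known or untested is meant among the compounds shown, and "the series" means these compounds.

Measured so far in an ADME assay on Raji cells (Homo sapiens) for cytotoxicity, with a stated time of 72 h; a lower number here means that less compound is needed, a higher number that more compound is needed for the effect:
- compound 1 `O=C(Nc1cc(-c2nc3ccccc3s2)ccc1Cl)c1cc([N+](=O)[O-])ccc1Cl` gives a limit of > 25000 nM, not a number.
- compound 2 `O=C(Nc1nc(-c2ccc(Cl)cc2)cs1)c1cc([N+](=O)[O-])ccc1Cl` gives 12000 nM.
- compound 3 `Cc1ccc(-c2nc3ccccc3o2)cc1NC(=O)c1cc([N+](=O)[O-])ccc1Cl` gives a limit of > 14000 nM, not a number.

Among the measured compounds shown here, compound 2 thus stands as the only compound of the three with an actual number in this assay; the other two values are limits. For the measured compounds named here, no two measured compounds differ in one place, so no measured step is available to lean on. Compound 4 `O=C(Nc1nc(-c2ccc(F)c(F)c2)cs1)c1cc([N+](=O)[O-])ccc1Cl` is the next compound, as yet unmeasured in this assay. Relative to compound 2 the change is 3,4-difluorophenyl in place of 4-chlorophenyl on an aromatic carbon, the 4-chlorophenyl leaving and the 3,4-difluorophenyl entering on the aromatic carbon, with the rest of the molecule kept.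

With nothing measured for this kind of change in the series, the expectation is a step of a 1.3-fold higher number from compound 2 to compound 4 (0.10 log units; within the scatter) that stays within the usual scatter, in either direction. The shared amide and nitro-bearing ring are unchanged, and compound 2 with 12000 nM is the only anchor. Compound 4 is therefore expected to give about 15000 nM in this assay, with a plausible range from 6000 nM to 40000 nM, and a real chance that only a limit is reported.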

Compound 4, half-maximal effective concentration: 13000 nM
Compound 4: the middle estimate sits 1.2-fold (0.06 log units) above what was measured; the range from low to high includes it.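

In this assay, putting 3,4-difluorophenyl in place of 4-chlorophenyl on the aromatic carbon next to the ring nitrogen gives a 1.1-fold higher number from compound 2 to compound 4 (0.03 log units; within the scatter) and so leaves the read-out unchanged within the usual variation. Among the compounds shown here, this is the first step between two compounds that differ in one place, and it shows that this position accepts this exchange of halogen-bearing phenyl groups with the rest of the molecule kept. Nothing shown gives a reason for this flat step, since the only further information consists of limits for compounds that differ from this pair in more than one place.

For the compounds shown here, only two halogen-bearing phenyl groups have been compared at this position, so it remains open whether the read-out would stay flat with a carboxylic acid or an aminomethyl group on the phenyl ring, or with a piperidine in place of that ring. Compound 1 and compound 3 differ from compound 2 in more than one place, which leaves open how the other parts of the molecule contribute.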